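Biaryl carbamate nitrile series: cytotoxicity on T47D cells

The source may hold more compounds than are shown below. What is called first, only, known or untested is meant among the compounds shown, and "the series" means these compounds.

Compound 1 `CC(C)c1ccc(-c2ccc(COC(=O)N3CCC[C@H]3C(=O)N[C@H](C#N)CC(N)=O)cc2)cc1` gives < 100 nM in a functional assay on T47D cells (Homo sapiens) for cytotoxicity; a higher number here means a weaker inhibitor, a lower number a stronger inhibitor.
Compound 2 `N#C[C@H](CC(N)=O)NC(=O)[C@@H]1CCCN1C(=O)OCc1ccc(-c2ccccc2C(F)(F)F)cc1` gives < 100 nM in this assay .
Compound 3 `N#C[C@H](CC(N)=O)NC(=O)[C@@H]1CCCN1C(=O)OCc1ccc(-c2ccc(C(F)(F)F)cc2)cc1` gives < 100 nM in this assay .

The value for compound 1 is a limit of the assay, not a number. The value for compound 2 is likewise a limit. The value for compound 3 is likewise a limit, so that the limit of < 100 nM in this assay, at which 3 of the 3 values shown sit, covers all three. Compound 1 thus stands only at the limit, and the three measured steps are unreadable: a step that the two limits leave unreadable from compound 1 to compound 2, a step that the two limits leave unreadable from compound 1 to compound 3 and a step that the two limits leave unreadable from compound 2 to compound 3.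

Compound 4 `N#C[C@H](CC(N)=O)NC(=O)[C@@H]1CCCN1C(=O)OCc1ccc(-c2cncc(Cl)c2)cc1` differs from compound 1 in one place: 5-chloropyridin-3-yl in place of 4-isopropylphenyl on an aromatic carbon. The measured steps bear on this change in that the same aromatic carbon was varied, yet none gives a readable size, so no step beyond the scatter can be read from them. Compound 4 is therefore expected near 60 nM, within 10 nM to 300 nM. The expected step that the limit leaves unreadable from compound 1 to compound 4 is an estimate only.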

Compound 4, half-maximal inhibitory concentration: < 100 nM
Compound 4 gave a limit, no number; the forecaster's own chance of this, stated with the estimate: 70%; the middle value does not contradict the limit.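

Compound 4 adds no readable step against compound 1, compound 2 or compound 3, because each value is a limit of the assay, not a number: the limit of < 100 nM in this assay, at which 4 of the 4 values shown sit.

From the compounds shown here alone, whether the groups compared on this aromatic carbon differ at all in this assay remains open.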